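The compounds below may be only part of what the source reports. "The series", "measured", "known", "first", "only" and "open" are said of these compounds alone.

Measured so far:
compound 1 `COc1cc[nH]c1/C=C1\C(=O)Nc2ccc([N+](=O)[O-])c(N3CC[C@H](O)C3)c21` — 37 nM
compound 2 `COc1cc[nH]c1/C=C1\C(=O)Nc2ccc([N+](=O)[O-])c(N3CCC(O)CC3)c21` — < 10 nM

In a functional assay on RKO cells (Homo sapiens) for antiproliferative activity, read by MTT assay, with a stated time of 5 days (a lower number here means a stronger inhibitor, a higher number a weaker inhibitor), compound 1 gives 37 nM. For compound 2 the reading in this assay is a limit of the assay and not a number, < 10 nM, as marked by the limit of < 10 nM in this assay, at which 1 of the 2 values shown sits. Among the compounds with values here, the one step between the two, an at least 3.7-fold lower number from compound 1 to compound 2 (0.56 log units; beyond the scatter), shows that the 4-hydroxypiperidin-1-yl group on the aromatic carbon sits at the lower, stronger end of the two readings, with compound 2 at the floor of what this assay resolves.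

Compound 3 `COc1cc[nH]c1/C=C1\C(=O)Nc2ccc([N+](=O)[O-])c(-n3ccnc3)c21` differs from compound 2 in one place: 1H-imidazol-1-yl in place of 4-hydroxypiperidin-1-yl on an aromatic carbon. No measured step covers this kind of exchange; the only step shown compares two hydroxylated saturated rings, and it cannot say how far removing the ring hydroxyl donor and putting an aromatic ring in this place will move the number. Since compound 2 is already at the limit, any move beyond the scatter can only appear as a higher number. Compound 3 is therefore expected to come in above compound 2, by an estimated at least 3.0-fold higher number from compound 2 to compound 3 (0.47 log units; beyond the scatter), giving an estimated 30 nM in this assay, with a range from 8 nM to 120 nM.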

Compound 3, half-maximal inhibitory concentration: 3920 nM
Compound 3: middle estimate off by 130-fold (2.12 log units), on the low side; the measured number lies above the stated range.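

In this assay, this position does not accept every ring equally: exchanging the saturated hydroxylated rings for 1H-imidazol-1-yl on the aromatic carbon gives a 110-fold higher number from compound 1 to compound 3 (2.03 log units; beyond the scatter), a large step that is exact at both ends. The same exchange gives an at least 390-fold higher number from compound 2 to compound 3 (2.59 log units; beyond the scatter), which is also large, and the series now shows that the group ortho to a nitro group can shift this read-out strongly, something the step between the two saturated rings did not reveal. Compound 2 has a limit and not a number, < 10 nM, so the step that starts from it fixes only the smallest possible size of the change: the limit of < 10 nM in this assay, at which 1 of the 3 values shown sits.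

The exchange alters ring size, aromatic character and the count of hydrogen-bond donors together, and the compounds shown do not separate these. Open, on these data alone, is whether a plain piperidin-1-yl without the hydroxyl, a morpholin-4-yl or a 4-aminopiperidin-1-yl stays with compound 1 and compound 2, or whether a saturated five-membered ring with two nitrogens moves toward compound 3.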